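The source may hold more compounds than are shown below. What is called first, only, known or untested is meant among the compounds shown, and "the series" means these compounds.

The series rests on compound 1 `CCc1nc2c(o1)C(=O)C(NCCN(C)C)=CC2=O`, compound 2 `CCc1nc2c(o1)C(O)=C/C(=N\CCN(C)C)C2=O` and compound 3 `CCc1nc2c([nH]1)C(=O)/C(=N/CCN(C)C)C=C2O`, all tested in a functional assay on DU-145 cells (Homo sapiens) for antiproliferative activity, read by colorimetric assay; a higher number here means a weaker inhibitor, a lower number a stronger inhibitor. In this assay compound 1 gives 220 nM. Compound 2 gives 220 nM in this assay, level with compound 1 at the digits shown, so the two stand within the scatter of each other and no ordering between them can be read. For compound 3 this assay returns only a limit, > 10000 nM; > 10000 nM (2 entries), in both entries; that is a limit of the assay and not a number.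

Compound 4 `CN(C)CC/N=C1\C=C(O)c2oc(-c3ccccc3)nc2C1=O` has not yet been measured in this assay. It differs from compound 2 in one place: phenyl in place of ethyl on an aromatic carbon. Among the compounds with values here, no measured pair shows this change, so the direction of the step from compound 2 to compound 4 rests on the change alone, with nothing in the numbers to lean on. The expectation is that the step of a 1.4-fold higher number from compound 2 to compound 4 (0.13 log units; within the scatter) stays close to the scatter, with no strong lean in either direction. Compound 4 is expected to give 300 nM in this assay, with a range from 60 nM to 2000 nM. Within the data shown here, the range is kept wide: no measured compound carries this change, and the numbers that exist are too few to narrow it.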

Compound 4, half-maximal inhibitory concentration: 210 nM
Compound 4: middle estimate off by 1.4-fold (0.15 log units), on the high side; measured number inside the range.
By their numbers in this assay, from the lowest: compounds 4, 1 and 2 (each within the scatter of the next).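

In this assay, phenyl in place of ethyl on an aromatic carbon of the five-membered aromatic ring gives a 1.0-fold lower number from compound 2 to compound 4 (0.02 log units; within the scatter). Compounds 1, 2 and 3 all carry ethyl here and so say nothing about this position, whereas this pair, the first to vary it, shows that 6 heavy atoms and a six-membered aromatic ring of carbon only can replace the 2 heavy atoms of ethyl with no readable shift in the antiproliferative read-out. No supporting data bear on why the two groups stand level, and the pair itself gives no reason.

What the compounds shown leave open is whether this level holds only for ethyl and phenyl or extends to other groups at the same carbon, such as a primary amine, a carboxylic acid, a longer chain like n-butyl, or a pyridine ring. A single pair also cannot say whether phenyl in place of ethyl would give the same result on a core other than that of compound 2.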